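Longer Aminoalkyl Chain on a Dialkylated Fragment

The source may hold more compounds than are shown below. What is called first, only, known or untested is meant among the compounds shown, and "the series" means these compounds.

Among the measured compounds shown here, compound 3 `CCCCCCCCCO[C@@H]1[C@@H](N)[C@@H](OCC(O)CNCCN)O[C@H](CN)[C@H]1OCCCCCCCCC` is tested in a toxicity assay on the whole organism (J774 cells) for cytotoxicity, with Mus musculus as the target, read by MTT assay, with a stated time of 24 h, tested at 30 uM (a higher number here means a weaker effect of the compound at the concentration tested, a lower number a stronger effect), and gives 53%, a number no other compound here exceeds. Compound 1 `CCCCCCCCCO[C@@H]1[C@@H](N)[C@@H](O[C@H]2[C@H](O)[C@@H](O)[C@H](N)C[C@@H]2N)O[C@H](CN)[C@H]1OCCCCCCCCC` gives 48.6% in this assay, and the change a number 4.4 percentage points higher from compound 1 to compound 3 (within the scatter) stays within the scatter. Compound 2 `CCCCCCCCCO[C@@H]1[C@@H](N)[C@@H](OCC(O)CNCCO)O[C@H](CN)[C@H]1OCCCCCCCCC` gives 10.1% in this assay, and the change a number 42.9 percentage points higher from compound 2 to compound 3 (beyond the scatter) is large, as is a number 38.5 percentage points lower from compound 1 to compound 2 (beyond the scatter).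

Compound 4 `CCCCCCCCCO[C@@H]1[C@@H](N)[C@@H](OCC(O)CNCCCN)O[C@H](CN)[C@H]1OCCCCCCCCC` differs from compound 3 by aminomethyl in place of amino on a saturated chain carbon, two bonds along the chain from an amine nitrogen, which read one bond further out is (2-aminoethyl)amino to (3-aminopropyl)amino. The amine that distinguishes compound 3 from compound 2 in a number 42.9 percentage points higher from compound 2 to compound 3 (beyond the scatter) is kept in compound 4. For the measured compounds named here, the only step at the same place, a number 42.9 percentage points higher from compound 2 to compound 3 (beyond the scatter), compares hydroxy with amino and says nothing about chain length, and no other measured step covers this kind of change. A step within the scatter is therefore expected for no change at the digits printed from compound 3 to compound 4 (within the scatter). Compound 4 is estimated at 53% in this assay, with a range from 38% to 68%.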

Compound 4, a percentage reported as activity, at one concentration (the size of the read-out at that concentration, not a potency): 71.6%
The estimate for compound 4 lay 18.6 percentage points below the measured number, outside the stated range (above it).
By their numbers in this assay, from the lowest: compound 2; then compounds 1 and 3 (each within the scatter of the next); then compound 4.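

In this assay, the length of this chain matters on its own: the change from (2-aminoethyl)amino to (3-aminopropyl)amino gives a number 18.6 percentage points higher from compound 3 to compound 4 (beyond the scatter) and so shows a weaker effect at the concentration tested, which the hydroxy-to-amino comparison could not show. The longer chain widens the distance from the hydroxy-ended side chain, with a number 61.5 percentage points higher from compound 2 to compound 4 (beyond the scatter) and, unlike the shorter amine chain, it also separates from the 4,6-diamino-2,3-dihydroxycyclohexyl group, with a number 23 percentage points higher from compound 1 to compound 4 (beyond the scatter) as the step on that oxygen. Nothing available explains what the added carbon does here.

Going by these compounds, two chain lengths set no trend, so it stays open whether (4-aminobutyl)amino would continue the rise or reverse it. On these data alone, it is equally open whether a dimethylamino group at the chain end would read like the primary amine.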